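Replacing the trifluoromethylphenyl arm of compound 3 with a trifluorophenyl

The source may hold more compounds than are shown below. What is called first, only, known or untested is meant among the compounds shown, and "the series" means these compounds.

Three compounds share one core and differ only in the aryl group on the ring amine nitrogen. Compound 1 `Nc1scc(CN2CCN(c3cc(Cl)cc(Cl)c3)CC2)c1C(=O)c1ccc(Cl)cc1` gives -74% in a functional assay on CHO cells with adenosine receptor A1 (Homo sapiens) as the target, read by cAMP accumulation and immunoassay, with a stated time of 6 min, tested at 10 uM (a higher number here means a weaker effect of the compound at the concentration tested, a lower number a stronger effect), and compound 2 `Nc1scc(CN2CCN(c3cccc(C(F)(F)F)c3)CC2)c1C(=O)c1ccc(Cl)cc1` gives -80%, the two values differing by a number 6 percentage points lower from compound 1 to compound 2 (within the scatter). Compound 3 `Nc1scc(CN2CCN(c3ccccc3C(F)(F)F)CC2)c1C(=O)c1ccc(Cl)cc1` gives -60%, the highest of the three numbers and thus the weakest effect shown so far, standing a number 14 percentage points higher from compound 1 to compound 3 (beyond the scatter) and a number 20 percentage points higher from compound 2 to compound 3 (beyond the scatter).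

Compound 4 `Nc1scc(CN2CCN(c3c(F)cc(F)cc3F)CC2)c1C(=O)c1ccc(Cl)cc1` is the next step from compound 3: 2,4,6-trifluorophenyl in place of 2-(trifluoromethyl)phenyl on an amine nitrogen in a ring. Going by the values given here, the only steps that bear on it are those leading into compound 3, which both raised the number by a modest amount when the 2-(trifluoromethyl)phenyl entered. The change to 2,4,6-trifluorophenyl removes that group, so a shift back toward the values of compound 1 and compound 2 is expected, though the new group resembles none already measured and the size is uncertain. Compound 4 is therefore estimated at -68%, within a range of -84% to -50%, an expected step of a number 8 percentage points lower from compound 3 to compound 4 (within the scatter).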

Compound 4, a percentage reported as activity, at one concentration (the size of the read-out at that concentration, not a potency): -78%
Estimate against measurement, compound 4: 10 percentage points above; measured number inside the range.
By their numbers in this assay, from the lowest: compounds 2, 4 and 1 (each within the scatter of the next); then compound 3.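

Going from 2-(trifluoromethyl)phenyl to 2,4,6-trifluorophenyl on the amine nitrogen in a ring gives a number 18 percentage points lower from compound 3 to compound 4 (beyond the scatter) in this assay and so shows that this position can recover from the value of compound 3 with a group of similar size, one heavy atom smaller by the count. Compound 3 is now the only one of the four set apart, since the new arm gives a number 2 percentage points higher from compound 2 to compound 4 (within the scatter) and a number 4 percentage points lower from compound 1 to compound 4 (within the scatter) and so cannot be told from the 3-(trifluoromethyl)phenyl or 3,5-dichlorophenyl arms. No measurement here explains why the 2-(trifluoromethyl)phenyl arm stands apart.

As far as these compounds go, all four arms are halogen-bearing or trifluoromethyl-bearing phenyl groups, so the shared core's response to a plain phenyl, a methoxyphenyl or a pyridyl ring at this nitrogen stays open. These are also readings at one concentration, so they give the size of the effect at that concentration only and leave open how compounds 1, 2 and 4 would compare at any other.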